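A Repeated Nitro-for-Hydroxy Swap and Its Expected Step

The source may report more compounds than this note shows. Statements on the series, on what has been measured and on what is new or still open speak of the compounds shown alone.

Compound 1 `COc1cc(OC)c2sc(-c3ccc(N/C=C\C(=O)c4ccc(OC)c(O)c4)c(C)c3)nc2c1` was tested in a functional assay on HeLa cells (Homo sapiens) for antiproliferative activity, read by sulforhodamine B assay, with a stated time of 48 h (a lower number here means a stronger inhibitor, a higher number a weaker inhibitor), where compound 1 gives 16100 nM. Compound 2 `COc1cc(OC)c2sc(-c3ccc(N/C=C\C(=O)c4ccc(OC)c([N+](=O)[O-])c4)c(C)c3)nc2c1` differs from compound 1 only by nitro in place of hydroxy on an aromatic carbon. In this assay compound 2 gives 9390 nM, and the step is a 1.7-fold lower number from compound 1 to compound 2 (0.23 log units; within the scatter).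

Compound 3 `COc1ccc(C(=O)/C=C\Nc2ccc(-c3nc4cc(OC)c(OC)c(OC)c4s3)cc2)cc1O` carries a core that is not the same as the core of compound 1; the difference between the two cores is not broken down here. In this assay, for the measured compounds named here, compound 3 gives 14100 nM, a number that sits close to the value of compound 1 and within the scatter of both compounds measured so far.

Compound 4 `COc1ccc(C(=O)/C=C\Nc2ccc(-c3nc4cc(OC)c(OC)c(OC)c4s3)cc2)cc1[N+](=O)[O-]` has not yet been measured. It differs from compound 3 by nitro in place of hydroxy on an aromatic carbon. The surroundings of the exchanged group are described in the same words as for the change from compound 1 to compound 2: on an aromatic carbon of a six-membered aromatic ring of carbon only, ortho to a methoxy group, meta to a large group. It is therefore the same change, made a second time on a different core.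

Going by the values given here, the expected step from compound 3 to compound 4 in this assay is a 1.7-fold lower number from compound 3 to compound 4 (0.22 log units; within the scatter), which rests on the only precedent, a 1.7-fold lower number from compound 1 to compound 2 (0.23 log units; within the scatter), a step that stayed within the scatter. The estimated value for compound 4 in this assay is 8500 nM, expected to lie between 3500 nM and 20000 nM.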

Compound 4, half-maximal inhibitory concentration: 11400 nM
Beside the measured number, compound 4's estimate is 1.3-fold (0.13 log units) below it; measured number inside the range.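

In this assay, putting nitro in place of hydroxy on the core of compound 3 gives a 1.2-fold lower number from compound 3 to compound 4 (0.09 log units; within the scatter). Set beside the earlier exchange, the two steps do not differ: the same change on two cores in this assay, a 1.7-fold lower number (0.23 log units; within the scatter) from compound 1 to compound 2 and a 1.2-fold lower number (0.09 log units; within the scatter) from compound 3 to compound 4, 1.4-fold (0.14 log units) apart, within the scatter of two such steps This shows that the change from 3-hydroxy-4-methoxyphenyl to 4-methoxy-3-nitrophenyl carries from the core of compound 1 to the core of compound 3 with the same outcome, a step that stays within the scatter on both, but it does not show that nitro gives a stronger inhibitor than hydroxy in either pair, and two cores tested in a single assay say nothing about how the change would behave on any other core.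

The compounds shown carry only hydroxy or nitro on this aromatic carbon, so it remains open whether an amine, a carboxylic acid or a fluorine atom in the same place would give a step beyond the scatter. From the compounds shown here alone, it also remains open whether a longer chain in place of the methoxy group would alter the result of this exchange on either core.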